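From compound 3 to compound 4: one added methoxy

The source may report more compounds than this note shows. Statements on the series, on what has been measured and on what is new or still open speak of the compounds shown alone.

In a functional assay on HepG2 cells (Homo sapiens) for antiproliferative activity, read by sulforhodamine B assay, with a stated time of 48 h (on this read-out higher numbers stand for weaker inhibition and lower numbers for stronger inhibition), compound 1 (`COc1ccc(C(=O)/C=C/c2ccccc2-c2ccc(F)cc2)cc1`) gives 6300 nM, compound 2 (`COc1ccc(C(=O)/C=C/c2ccccc2-c2ccc(F)cc2)cc1OC`) gives 6600 nM and compound 3 (`O=C(/C=C/c1ccccc1-c1ccc(F)cc1)c1cccc(O)c1`) gives 4200 nM. Compound 3 thus lies within the scatter of both others, and no order can be read among the three. Compound 4 (`COc1ccc(C(=O)/C=C/c2ccccc2-c2ccc(F)cc2)cc1O`) departs from compound 3 by methoxy in place of hydrogen on an aromatic carbon, a methoxy in place of hydrogen on an aromatic carbon. The same kind of exchange gave a 1.0-fold higher number from compound 1 to compound 2 (0.02 log units; within the scatter), and the exchange of 4-methoxyphenyl for 3-hydroxyphenyl gave a 1.5-fold lower number from compound 1 to compound 3 (0.18 log units; within the scatter). Neither step exceeds the scatter, so no change beyond it is expected here. The expected step is a 1.1-fold higher number from compound 3 to compound 4 (0.06 log units; within the scatter). Compound 4 is estimated at 4800 nM, with an expected range of 2400 nM to 9500 nM.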

Compound 4, half-maximal inhibitory concentration: 190 nM
Compound 4: the middle estimate sits 25-fold (1.40 log units) above what was measured; the measured number lies below the stated range.
By their numbers in this assay, from the lowest: compound 4; then compounds 3, 1 and 2 (each within the scatter of the next).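

In this assay, the methoxy's effect depends on its surroundings among these compounds, and it counts when it stands ortho to a hydroxy group, with a 22-fold lower number from compound 3 to compound 4 (1.34 log units; beyond the scatter); the same exchange does not carry over from the core of compound 1: the same change on two cores in this assay, a 1.0-fold higher number (0.02 log units; within the scatter) from compound 1 to compound 2 and a 22-fold lower number (1.34 log units; beyond the scatter) from compound 3 to compound 4, 23-fold (1.36 log units) apart, beyond the scatter of two such steps The hydroxy group is needed as well, with a 33-fold lower number from compound 1 to compound 4 (1.52 log units; beyond the scatter) when it is added. Capping its oxygen with methyl loses the gain, and removing that methyl gives a 35-fold lower number from compound 2 to compound 4 (1.54 log units; beyond the scatter). The compounds shown leave open whether an amine could stand in for this hydroxy group, and whether an ethoxy could stand in for the methoxy.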